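The source may hold more compounds than are shown below. What is called first, only, known or untested is meant among the compounds shown, and "the series" means these compounds.

Measured so far in a functional assay on HCT-116 cells (Homo sapiens) for inhibition, read by sulforhodamine B assay, with a stated time of 3 days; on this read-out lower numbers stand for stronger inhibition and higher numbers for weaker inhibition:
- compound 1 `COc1ccc(C(=O)Nc2ccc3c(c2)/C(=C/Nc2cccc(N4CCN(C)CC4)c2)C(=O)N3)cc1` gives 2010 nM in this series
- compound 2 `CN1CCN(c2cccc(N/C=C3\C(=O)Nc4ccc(NC(=O)c5cccc(F)c5)cc43)c2)CC1` gives 2740 nM in this series

These two values lie within the scatter of each other, so compound 2 cannot be ranked against compound 1. Compound 3 `CN1CCN(c2cccc(N/C=C3\C(=O)Nc4ccc(NC(=O)c5c(F)cccc5F)cc43)c2)CC1` carries 2,6-difluorophenyl in place of 3-fluorophenyl on a carbonyl carbon. Going by the values given here, the only measured step at that carbonyl carbon, 3-fluorophenyl in place of 4-methoxyphenyl, is small (a 1.4-fold higher number from compound 1 to compound 2 (0.13 log units; within the scatter)), and on that basis no step beyond the scatter is expected in this assay for this change. Among the compounds with values here, no measured compound carries 2,6-difluorophenyl, so the range is kept wide. The expected step stays small (a 1.1-fold lower number from compound 2 to compound 3 (0.04 log units; within the scatter)). For compound 3 the estimate is 2500 nM with an expected range from 1000 nM to 6000 nM in this read-out.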

Compound 3, half-maximal inhibitory concentration: 2150 nM
Compound 3: middle estimate off by 1.2-fold (0.07 log units), on the high side; the range from low to high includes it.
By their numbers in this assay, from the lowest: compounds 1, 3 and 2 (each within the scatter of the next).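

The aryl group on the carbonyl carbon now has three forms in this assay, and the new readings are the step of a 1.3-fold lower number from compound 2 to compound 3 (0.11 log units; within the scatter) and the step of a 1.1-fold higher number from compound 1 to compound 3 (0.03 log units; within the scatter) with both lying within the scatter. Neither 2,6-difluorophenyl in place of 3-fluorophenyl nor 2,6-difluorophenyl in place of 4-methoxyphenyl gives a readable change at this position, so compound 1, compound 2 and compound 3 cannot be ranked. Nothing at hand gives a cause for this flat result.

From the compounds shown here alone, all three compounds carry a substituted phenyl on this carbonyl carbon, so it remains open whether any group there can shift the number beyond the scatter. A phenyl bearing a carboxylic acid or a dimethylaminomethyl group, or a morpholine in place of the phenyl, would put that question to the series.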